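The source may hold more compounds than are shown below. What is called first, only, known or untested is meant among the compounds shown, and "the series" means these compounds.

Among the compounds with values here, compound 1 `O=C(CCC(=O)OCCCCCCSc1ccc([N+](=O)[O-])c2nonc12)Nc1ccccc1` is the stronger of the two compounds measured so far in an assay on isolated protein for inhibition of glutathione S-transferase Mu 2 (Homo sapiens), with a stated time of 10 min (on this read-out higher numbers stand for weaker inhibition and lower numbers for stronger inhibition), where compound 1 gives 700 nM. Within the data shown here, its only measured neighbour, compound 2 `O=C(CCC(=O)OCCCCCCSc1ccc([N+](=O)[O-])c2nonc12)Nc1ccc(Br)cc1`, gives 32000 nM, and the step of a 46-fold higher number from compound 1 to compound 2 (1.66 log units; beyond the scatter) shows that a small change at the anilide end of the molecule can move the number a long way. Compound 3 `CN(C)CCNC(=O)CCC(=O)OCCCCCCSc1ccc([N+](=O)[O-])c2nonc12` differs from compound 1 in the same region, but in a different way: 2-(dimethylamino)ethyl in place of phenyl on an amide-type nitrogen. Among the measured compounds shown here, no measured step covers this exchange, so the bromo step can only serve as a sign that the amide-bearing end of the shared core is sensitive to alteration. On that basis the expected step is estimated as a 4.3-fold higher number from compound 1 to compound 3 (0.63 log units; beyond the scatter), a sizeable shift toward weaker inhibition with wide uncertainty in both directions. Compound 3 is therefore estimated at 3000 nM, within a range from 500 nM to 20000 nM.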

Compound 3, half-maximal inhibitory concentration: 160 nM
The estimate for compound 3 lay 19-fold (1.27 log units) above the measured number; the whole stated range lies above it.
By their numbers in this assay, from the lowest: compound 3; then compound 1; then compound 2.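

In this assay, a change at this amide-type nitrogen can also go toward stronger inhibition: 2-(dimethylamino)ethyl in place of phenyl gives a 4.4-fold lower number from compound 1 to compound 3 (0.64 log units; beyond the scatter). The phenyl ring of compound 1 is therefore not needed for the lowest number seen so far, and an open chain with no ring reaches it. Set against the 4-bromophenyl group, the same exchange gives a 200-fold lower number from compound 2 to compound 3 (2.30 log units; beyond the scatter), the widest gap among the three compounds, so this one position spans a large range of inhibition.

Compound 3 loses the ring and gains the amine nitrogen in a single change, and the compounds shown do not separate the two. As far as these compounds go, how a plain alkyl chain with no amine, a carboxylic acid, or a longer chain carrying the amine would read at this nitrogen stays open. No independent measurement is at hand to explain the direction of either step.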